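Four-membered ring returns, chlorine added: working notes

The source may report more compounds than this note shows. Statements on the series, on what has been measured and on what is new or still open speak of the compounds shown alone.

Measured in a functional assay on the whole organism for antagonist activity, with Rattus norvegicus as the target; a lower number here means that less compound is needed, a higher number that more compound is needed for the effect:
- compound 1 `c1ccc2c(c1)CC2CCCCN1CCN(c2cccc3c2OCCO3)CC1` gives 1.43 mg/kg
- compound 2 `c1ccc2c(c1)CCC2CCN1CCN(c2cccc3c2OCCO3)CC1` gives 1.29 mg/kg
- compound 3 `c1ccc2c(c1)CCC2CCCN1CCN(c2cccc3c2OCCO3)CC1` gives 0.29 mg/kg

Compound 3 has the lowest of the three numbers, and its gaps to compound 1 and compound 2 both lie beyond the scatter. Compound 4 `Clc1cccc2c1CC2CCCN1CCN(c2cccc3c2OCCO3)CC1` differs from it as follows: a group of 9 heavy atoms (8 carbon, 1 chlorine; one four-membered non-aromatic ring of carbon only, one six-membered aromatic ring of carbon only) in place of a group of 9 heavy atoms (9 carbon; one five-membered non-aromatic ring of carbon only, one six-membered aromatic ring of carbon only), on a saturated chain carbon, three bonds along the chain from an amine nitrogen in a ring. Among the compounds with values here, the one measured step bearing on this is a 4.9-fold lower number from compound 1 to compound 3 (0.69 log units; beyond the scatter), which brought in a five-membered ring group in place of a four-membered one. Compound 4 returns to a four-membered ring, so that step is read in reverse. Within the data shown here, no measured step covers the chlorine. The expected step is a 2.9-fold higher number from compound 3 to compound 4 (0.47 log units; beyond the scatter) in this assay, towards a higher number. For compound 4 the estimated value is 0.85 mg/kg, with an expected range from 0.3 mg/kg to 2.4 mg/kg.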

Compound 4, dose for 50% inhibition: 3.09 mg/kg
Compound 4: middle estimate off by 3.6-fold (0.56 log units), on the low side; measured number outside the range, above it.
By their numbers in this assay, from the lowest: compound 3; then compounds 2 and 1 (each within the scatter of the next); then compound 4.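

In this assay, the chlorine-bearing group with the four-membered ring at this position gives a large rise (an 11-fold higher number from compound 3 to compound 4 (1.03 log units; beyond the scatter)), so this swap gives no gain over the 2,3-dihydro-1H-inden-1-yl group. Against the chlorine-free group with the four-membered ring, the same kind of group gives a smaller rise (a 2.2-fold higher number from compound 1 to compound 4 (0.33 log units; beyond the scatter)), which still lies beyond the scatter. No supporting measurement accounts for either rise.

Ring size and chlorine change together in the larger step, so their shares stay unseparated. Open too, as far as these compounds go, is how 2,3-dihydro-1H-inden-1-yl would respond to chlorine or a methoxy group on its aromatic ring.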